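A few compounds are considered here, and "the series" means these few. Any claim that something is new, unique, unknown or untested is made for them only; others in the source may bear on it.

Measured in a toxicity assay on CHO cells (Cricetulus griseus) for cytotoxicity, read by WST assay, with a stated time of 24 h; on this read-out higher numbers stand for weaker inhibition and lower numbers for stronger inhibition:
Compound 1 `CC(C)=CCC/C(C)=C\CCC(C)=CCNCCCCN`: 18100 nM
Compound 2 `CC(C)=CCC/C(C)=C\CCC(C)=CCNCCCCCN`: 38400 nM

Compound 2 holds the higher of the two numbers in this assay. Compound 3 `CC(C)=CCC/C(C)=C\CCC(C)=CCNCCCCCCCCCCCCN` differs from it by 7-aminoheptyl in place of amino on a saturated chain carbon, five bonds along the chain from an amine nitrogen. Among the measured compounds shown here, only one measured step bears on this, a 2.1-fold higher number from compound 1 to compound 2 (0.33 log units; beyond the scatter), and it reflects a far smaller change, aminomethyl in place of amino. Its direction cannot safely be extended that far, so a moderate move toward stronger inhibition is tentatively expected. The estimated step is a 2.6-fold lower number from compound 2 to compound 3 (0.41 log units; beyond the scatter). For compound 3 the estimated value is 15000 nM, with an expected range of 3000 nM to 60000 nM.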

Compound 3, half-maximal inhibitory concentration: 25300 nM
Compound 3: middle estimate off by 1.7-fold (0.23 log units), on the low side; the range from low to high includes it.
By their numbers in this assay, from the lowest: compounds 1, 3 and 2 (each within the scatter of the next, the first and the last beyond it).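

In this assay the much larger 7-aminoheptyl change gives a 1.5-fold lower number from compound 2 to compound 3 (0.18 log units; within the scatter) and the 8-aminooctyl change gives a 1.4-fold higher number from compound 1 to compound 3 (0.15 log units; within the scatter) with both steps within the scatter. Among the compounds shown here, at this place on the chain, then, a far longer chain ending in an amine stays within the scatter of both shorter compounds, which the single earlier step could not show. No evidence bearing on the reason for this result is available.

Still open, from the compounds shown here alone, is whether a chain longer than 8-aminooctyl would stay in this band, and whether a carboxylic acid or a hydroxyl at the chain end would do the same.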